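Ester series: pentyl to phenyl on the ester oxygen

The source may report more compounds than this note shows. Statements on the series, on what has been measured and on what is new or still open speak of the compounds shown alone.

In an ADME assay on RAW264.7 cells (Mus musculus) for cytotoxicity, read by MTT assay, with a stated time of 24 h (on this read-out higher numbers stand for lower toxicity in this test and lower numbers for higher toxicity in this test), compound 1 `CC/C=C\C[C@H]1C(=O)C=C[C@H]1CC(=O)OCC` gives 146 uM, compound 2 `CC/C=C\C[C@H]1C(=O)C=C[C@H]1CC(=O)OCCC` gives 35 uM and compound 3 `CC/C=C\C[C@H]1C(=O)C=C[C@H]1CC(=O)OCCCCC` gives 37 uM. Compound 3 therefore lies within the scatter of compound 2, and both lie clearly under compound 1.

Compound 4 `CC/C=C\C[C@H]1C(=O)C=C[C@H]1CC(=O)Oc1ccccc1` carries one change from compound 3: phenyl in place of pentyl on an oxygen next to a carbonyl group. Among the measured compounds shown here, no measured compound has a ring at this place, so the measured steps bear on it only indirectly. The chain changes gave a 4.2-fold lower number from compound 1 to compound 2 (0.62 log units; beyond the scatter) and a 3.9-fold lower number from compound 1 to compound 3 (0.60 log units; beyond the scatter), both modest, but a 1.1-fold higher number from compound 2 to compound 3 (0.02 log units; within the scatter) stayed within the scatter. The last of these is the closest guide, as it compares the two longer chains. The modest steps set the width of the range, and no shift beyond the scatter is expected in either direction.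

The expected step is a 1.2-fold lower number from compound 3 to compound 4 (0.06 log units; within the scatter). Compound 4 is estimated at 32 uM, with an expected range of 12 uM to 95 uM.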

Compound 4, half-maximal toxic concentration: 158 uM
Beside the measured number, compound 4's estimate is 4.9-fold (0.69 log units) below it; the whole stated range lies below it.
By their numbers in this assay, from the lowest: compounds 2 and 3 (each within the scatter of the next); then compounds 1 and 4 (each within the scatter of the next).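

In this assay, phenyl in place of pentyl on an oxygen next to a carbonyl group gives a 4.3-fold higher number from compound 3 to compound 4 (0.63 log units; beyond the scatter) and phenyl in place of propyl gives a 4.5-fold higher number from compound 2 to compound 4 (0.65 log units; beyond the scatter); this first ring at the position therefore separates from both the propyl and pentyl esters, which differ from each other only within the scatter. Phenyl in place of ethyl gives a 1.1-fold higher number from compound 1 to compound 4 (0.03 log units; within the scatter), so the ethyl and phenyl esters stand together and the four compounds show no steady trend with the number of heavy atoms in the group. No measured information at hand accounts for this split.

Going by these compounds, whether the aromatic ring itself matters, or phenyl alone, stays open; cyclohexyl and benzyl on this oxygen would bear on that. On these data alone, how a methyl ester or the free carboxylic acid compares also remains open.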